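The source may report more compounds than this note shows. Statements on the series, on what has been measured and on what is new or still open speak of the compounds shown alone.

Of the compounds shown here, three have so far been measured in a functional assay on Jurkat cells (Homo sapiens) for inhibition; a higher number here means a weaker inhibitor, a lower number a stronger inhibitor. Compound 1 `CCOC(=O)c1c(C)noc1OCC(=O)[C@H](CC(=O)O)NC(=O)[C@@H](NC(=O)COc1cccc2ccccc12)C(C)C` gives > 200000 nM, which is a limit of the assay. Compound 2 `CC(C)[C@H](NC(=O)COc1cccc2ccccc12)C(=O)N[C@@H](CC(=O)O)C(=O)CSc1ncc[nH]1` gives > 200000 nM, again a limit. Compound 3 `CC(C)[C@H](NC(=O)COc1cccc2ccccc12)C(=O)N[C@@H](CC(=O)O)C(=O)CSc1nc(-c2ccccc2)no1` gives 102000 nM.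

Among the measured compounds shown here, compound 3 therefore holds the only number in this assay; the other two values are limits (the limit of > 200000 nM in this assay, at which 2 of the 3 values shown sit). The step from compound 1 to compound 2 stays unreadable, a step that the two limits leave unreadable from compound 1 to compound 2. The steps toward compound 3 are an at least 1.9-fold lower number from compound 1 to compound 3 (0.29 log units; that floor lies within the scatter) and an at least 1.9-fold lower number from compound 2 to compound 3 (0.29 log units; that floor lies within the scatter), each only a floor that lies within the scatter.

Compound 4 `Cc1nnc(SCC(=O)[C@H](CC(=O)O)NC(=O)[C@@H](NC(=O)COc2cccc3ccccc23)C(C)C)s1` differs from compound 3 in one place: 5-methyl-1,3,4-thiadiazol-2-yl in place of 3-phenyl-1,2,4-oxadiazol-5-yl on a sulfur. The step from compound 2 to compound 3 bears most directly on this change, since it also exchanged one five-membered ring on the sulfur for another, and its size, an at least 1.9-fold lower number from compound 2 to compound 3 (0.29 log units; that floor lies within the scatter), is a floor within the scatter. Compound 4 again carries a five-membered ring without the phenyl, so a number no lower than that of compound 3, and likely a return toward the limit, is expected in this assay, a 2.0-fold higher number from compound 3 to compound 4 (0.29 log units; within the scatter). Compound 4 is thus estimated at 200000 nM, within 80000 nM to 600000 nM.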

Compound 4, half-maximal inhibitory concentration: 190000 nM
For compound 4 the middle estimate is 1.1-fold (0.02 log units) above the measured one; low and high end bracket the measured number.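

In this assay, the exchange on the sulfur gives a 1.9-fold higher number from compound 3 to compound 4 (0.27 log units; within the scatter), so the 3-phenyl-1,2,4-oxadiazol-5-yl group with its 11 heavy atoms and the 5-methyl-1,3,4-thiadiazol-2-yl group with its 6 cannot be told apart here. Compound 4 also shows that a readable number at this position does not depend on a six-membered aromatic ring of carbon only. The steps from the two compounds held at the limit, an at least 1.0-fold lower number from compound 2 to compound 4 (0.02 log units; that floor lies within the scatter) and an at least 1.0-fold lower number from compound 1 to compound 4 (0.02 log units; that floor lies within the scatter), are only floors, and the limit still restricts what can be read at this position: the limit of > 200000 nM in this assay, at which 2 of the 4 values shown sit.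

Going by these compounds, it remains open whether any group on this sulfur can move the number beyond the scatter. How an amine or a carboxylic acid in place of the methyl of the 5-methyl-1,3,4-thiadiazol-2-yl group would read is also unknown.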